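The compounds below may be only part of what the source reports. "The series", "measured", "known", "first", "only" and "open" are said of these compounds alone.

Compound 1 `CC(C)c1ccc2nc(N)sc2c1` and compound 2 `CC(C)(C)c1ccc2nc(N)sc2c1` share one core; compound 3 `CCCn1c(=N)sc2cc(OC(F)(F)F)ccc21` and the still unmeasured compound 4 `CCCCn1c(=N)sc2cc(OC(F)(F)F)ccc21` share another, and the difference between the two cores is not broken down here. All of them belong to a functional assay on the whole organism with Rattus norvegicus as the target; a lower number here means that less compound is needed, a higher number that more compound is needed for the effect. For compound 1 the result is a limit of the method rather than a number, > 10 mg/kg. Compound 2 gives 4 mg/kg, and compound 3 gives 4.5 mg/kg. The change from compound 1 to compound 2 is methyl in place of hydrogen on a saturated chain carbon bound to an aromatic carbon and two saturated chain carbons, which, cut one bond further out, reads isopropyl to tert-butyl. It brought an at least 2.5-fold lower number from compound 1 to compound 2 (0.39 log units; beyond the scatter); the size of this step is known only as a lower bound because of the limit of > 10 mg/kg in this assay, at which 1 of the 3 values shown sits. The change from compound 3 to compound 4 is methyl in place of hydrogen on a saturated chain carbon, three bonds along the chain from an aromatic nitrogen, which reads propyl to butyl. It is the same kind of change, an added methyl, but not the same one: in compound 1 the carbon that takes it is bound to an aromatic carbon and two saturated chain carbons, whereas in compound 3 it lies three bonds along the chain from an aromatic nitrogen. Among the compounds with values here, since the only earlier step of this kind, an at least 2.5-fold lower number from compound 1 to compound 2 (0.39 log units; beyond the scatter), was measured in another core and has an open-ended size, the step expected here is a 1.3-fold lower number from compound 3 to compound 4 (0.11 log units; within the scatter), smaller and close to the scatter. Compound 4 is therefore expected to give about 3.5 mg/kg, most likely between 1.5 mg/kg and 9 mg/kg.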

Compound 4, dose for half-maximal effect: 10 mg/kg
Estimate against measurement, compound 4: 2.9-fold (0.46 log units) below, outside the stated range (above it).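

Going from propyl to butyl gave a 2.2-fold higher number from compound 3 to compound 4 (0.35 log units; beyond the scatter) in this assay, so more compound was needed, and the gain seen earlier when isopropyl became tert-butyl did not carry over to this second core; the two steps run in opposite directions and clearly differ: the same change on two cores in this assay, an at least 2.5-fold lower number (0.39 log units; beyond the scatter) from compound 1 to compound 2 and a 2.2-fold higher number (0.35 log units; beyond the scatter) from compound 3 to compound 4, at least 5.5-fold (0.74 log units) apart, beyond the scatter of two such steps

The earlier step has only a minimum size, since compound 1 rests on a limit of the method rather than a number: the limit of > 10 mg/kg in this assay, at which 1 of the 4 values shown sits.

This shows that, in these compounds, the result of adding a methyl on one core cannot simply be transferred to the other, but it does not show why: the two steps differ both in the core and in the carbon that takes the methyl, and two steps cannot separate these.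

On these data alone, whether the rise continues with a longer chain such as pentyl, or whether a shorter ethyl chain would need still less compound than propyl, stays open. Also open, as far as these compounds go, is what a propyl and a butyl chain would give on the core of compound 1, a pair that would help to separate the role of the core from that of the carbon changed.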